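Chain branching at the carbon on the double-bonded nitrogen

This account rests on a few compounds, and the source may have more. Where it says the series, first, only, none or still open, it means among the compounds named here.

Measured in a functional assay on the whole organism (blood, strain Wistar-Okamoto) with Rattus norvegicus as the target, with a stated time of 5 days; a lower number here means that less compound is needed, a higher number that more compound is needed for the effect:
compound 1 `CCCC/N=C(\NC#N)Nc1cccnc1`: 20 mg/kg
compound 2 `CCCC(C)(C)/N=C(\NC#N)Nc1cccnc1`: 1 mg/kg

Going by the values given here, compound 2 holds the lower of the two numbers; the one measured step, a 20-fold lower number from compound 1 to compound 2 (1.30 log units; beyond the scatter), is large and beyond the scatter. Compound 3 `CC(C)C(C)(C)/N=C(\NC#N)Nc1cccnc1` differs from compound 2 by isopropyl in place of propyl on a saturated chain carbon bound to a double-bonded nitrogen and two saturated chain carbons. Among the compounds with values here, the measured step concerns the two methyls on the chain carbon itself, not the shape of the chain beyond it, so no measured step bears directly on this change. Compound 3 is therefore expected to sit close to compound 2, with no change at the digits printed from compound 2 to compound 3 (within the scatter) expected to stay within the scatter. The estimate for compound 3 is 1 mg/kg, range 0.4 mg/kg to 3 mg/kg.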

Compound 3, minimum effective dose: 1 mg/kg
Compound 3: the middle estimate sits on the measured number at the digits printed; low and high end bracket the measured number.
By their numbers in this assay, from the lowest: compounds 2 and 3 (each within the scatter of the next); then compound 1.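

In this assay, the change from 1,1-dimethylbutyl to 1,1,2-trimethylpropyl gives no change at the digits printed from compound 2 to compound 3 (within the scatter) and so leaves the number unmoved, with isopropyl in place of propyl on a saturated chain carbon bound to a double-bonded nitrogen and two saturated chain carbons. The large step from butyl is thus not confined to one branched group: 1,1,2-trimethylpropyl in place of butyl gives a 20-fold lower number from compound 1 to compound 3 (1.30 log units; beyond the scatter) on the same core. Going by these compounds, whether a tert-butyl group, a cyclohexyl group or a longer chain at this position keeps the number at this level stays open. Nothing measured here accounts for either step.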